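The source may report more compounds than this note shows. Statements on the series, on what has been measured and on what is new or still open speak of the compounds shown alone.

Compound 1 `CCOc1ccc(-c2cc3oc(=O)cc(C)c3cc2OS(=O)(=O)C(F)(F)F)cc1` carries a 4-ethoxyphenyl group on the shared core. In a toxicity assay on MT4 cells (Homo sapiens) for cytotoxicity, read by MTT assay, with a stated time of 5 days (on this read-out higher numbers stand for lower toxicity in this test and lower numbers for higher toxicity in this test), compound 1 gives only a limit of the assay, >= 27.2 ug/mL, and not a number. Two other compounds on the same core have full numbers. Compound 2 `Cc1cc(=O)oc2cc(-c3ccc(F)cc3)c(OS(=O)(=O)C(F)(F)F)cc12`, with a 4-fluorophenyl group, gives 10.6 ug/mL in this assay. Compound 3 `Cc1cccc(-c2cc3oc(=O)cc(C)c3cc2OS(=O)(=O)C(F)(F)F)c1`, with a 3-methylphenyl group, gives 61.3 ug/mL in this assay.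

Of the steps among these three, an at least 2.5-fold lower number from compound 1 to compound 2 (0.40 log units; beyond the scatter) came with fluoro in place of ethoxy; a step that the limit leaves unreadable from compound 1 to compound 3, its size not readable because compound 1 sits at the limit of >= 27.2 ug/mL in this assay, at which 1 of the 3 values shown sits; and a 5.8-fold higher number from compound 2 to compound 3 (0.76 log units; beyond the scatter) came with 3-methylphenyl in place of 4-fluorophenyl.

Compound 4 `Cc1cc(=O)oc2cc(-c3ccc(C(C)(C)C)cc3)c(OS(=O)(=O)C(F)(F)F)cc12` differs from compound 1 by tert-butyl in place of ethoxy on an aromatic carbon. The two steps with readable size both left the aryl substituent pattern and point in opposite directions, so only a modest movement in this assay, of either sign or none beyond the scatter, is expected from this change, with a fair chance that compound 4 again reaches only a limit. Compound 4 is therefore estimated at about 30 ug/mL, between 8 ug/mL and 80 ug/mL, in this assay. That estimate amounts to an expected step that the limit leaves unreadable from compound 1 to compound 4.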

Compound 4, half-maximal cytotoxic concentration: 10.3 ug/mL
The estimate for compound 4 lay 2.9-fold (0.46 log units) above the measured number; measured number inside the range.
By their numbers in this assay, from the lowest: compounds 4 and 2 (each within the scatter of the next); then compound 3.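

With tert-butyl in place of ethoxy on the aromatic carbon para to a large group, this assay shows an at least 2.6-fold lower number from compound 1 to compound 4 (0.42 log units; beyond the scatter), so a lower number on leaving ethoxy is no longer seen with fluoro alone. Tert-butyl and fluoro at this place cannot be told apart, with a 1.0-fold lower number from compound 2 to compound 4 (0.01 log units; within the scatter), while 4-(tert-butyl)phenyl in place of 3-methylphenyl gives a 6.0-fold lower number from compound 3 to compound 4 (0.77 log units; beyond the scatter), which leaves compound 3 clearly higher than both compound 2 and compound 4. The true size of the drop on leaving ethoxy remains unknown because compound 1 gives only a limit and not a number: the limit of >= 27.2 ug/mL in this assay, at which 1 of the 4 values shown sits.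

Going by these compounds, whether the higher number of compound 3 goes with the methyl group itself or with where that group sits on the ring stays open. Also open, on these data alone, is how an amine, a carboxylic acid or a chain longer than ethoxy would read at this place in this assay, so the likeness of fluoro and tert-butyl here cannot be extended to other groups.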